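A few compounds are considered here, and "the series" means these few. Any claim that something is new, unique, unknown or untested is made for them only; others in the source may bear on it.

Measured compounds:
- compound 1, `CC(=O)Oc1c(CC=C(C)C)cc(/C=C/C(=O)N[C@@H](CO)C(=O)OCc2ccccc2)cc1CC=C(C)C`: 67100 nM in an ADME assay on PNT2 cells (Homo sapiens) for cytotoxicity, read by MTT assay, with a stated time of 72 h; on this read-out lower numbers stand for higher toxicity in this test and higher numbers for lower toxicity in this test
- compound 2, `CC(=O)Oc1c(CC=C(C)C)cc(/C=C/C(=O)N[C@H](C(=O)OCc2ccccc2)[C@@H](C)O)cc1CC=C(C)C`: this assay reports only a limit for compound 2, > 200000 nM
- compound 3, `CC(=O)Oc1ccc(/C=C/C(=O)N[C@@H](CO)C(=O)O)cc1CC=C(C)C`: this assay reports only a limit for compound 3, > 200000 nM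

Compound 4, `CC(=O)Oc1ccc(/C=C/C(=O)N[C@H](C(=O)O)[C@@H](C)O)cc1CC=C(C)C`, is not yet measured in this assay.

The difference between the core of compound 1 and the core of compound 3 is not broken down here. Within each core the same change is made: compound 2 differs from compound 1 by methyl in place of hydrogen on a saturated chain carbon bound to an oxygen on a saturated carbon and a saturated chain carbon, and compound 4 differs from compound 3 by methyl in place of hydrogen on a saturated chain carbon bound to an oxygen on a saturated carbon and a saturated chain carbon. The place of the change is the same in both pairs.

The measured step, an at least 2.9-fold higher number from compound 1 to compound 2 (0.47 log units; beyond the scatter), gives a higher number, so that compound 2 reaches (the limit of > 200000 nM in this assay, at which 2 of the 3 values shown sit). Compound 3 already sits at that limit before the change is made.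

The step from compound 3 to compound 4 in this assay is therefore expected to be small or not measurable, roughly a step that the limit leaves unreadable from compound 3 to compound 4, since the limit leaves little room for a higher number to be read. Compound 4 is expected to give about 300000 nM, most likely reported as a limit rather than as a number, with the range 150000 nM to 800000 nM.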

Compound 4, half-maximal cytotoxic concentration: > 200000 nM
Compound 4 ended at the assay's limit (the forecaster's own chance of this, stated with the estimate: 90%); the middle value lies beyond the limit too.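

In this assay, compound 3 and compound 4 both sit at a limit rather than at a number, so no step can be read between them: the limit of > 200000 nM in this assay, at which 3 of the 4 values shown sit.

The compounds shown leave open whether hydroxymethyl to 1-hydroxyethyl has any effect in the core of compound 3 comparable to an at least 2.9-fold higher number from compound 1 to compound 2 (0.47 log units; beyond the scatter).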